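Chloro for Bromo at Two Positions of the Amide Ring

The source may hold more compounds than are shown below. What is called first, only, known or untested is meant among the compounds shown, and "the series" means these compounds.

Compound 1 `Cn1c(-c2ccc(Br)cc2)cnc1NC(=O)c1ccc(F)cc1` gives 46000 nM in a toxicity assay on THP-1 cells (Homo sapiens) for inhibition; on this read-out lower numbers stand for higher toxicity in this test and higher numbers for lower toxicity in this test.
Compound 2 `Cn1c(-c2ccc(Cl)cc2)cnc1NC(=O)c1ccc(F)cc1` gives 37000 nM in the same test.
Compound 3 `Cn1c(-c2ccccc2)cnc1NC(=O)c1cccc(Br)c1` gives > 50000 nM in the same test.

Compound 1 and compound 2 share one core and differ only by chloro in place of bromo on an aromatic carbon; this change made a step of a 1.2-fold lower number from compound 1 to compound 2 (0.09 log units; within the scatter). For compound 3 the test reports only a limit, not a number (the limit of > 50000 nM in this assay, at which 1 of the 3 values shown sits). How the core of compound 3 differs from that of compound 1 is not broken down here.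

Compound 4 `Cn1c(-c2ccccc2)cnc1NC(=O)c1cccc(Cl)c1` has not been measured. It differs from compound 3 by chloro in place of bromo on an aromatic carbon. The surroundings are not identical: in the first pair the group sits para to a large group, in the second meta to a large group, so this is the same kind of change, not the same change. Because a 1.2-fold lower number from compound 1 to compound 2 (0.09 log units; within the scatter) lies within the scatter, the step from compound 3 to compound 4 is expected to be small as well, a step that the limit leaves unreadable from compound 3 to compound 4. Compound 4 is therefore expected to give about 55000 nM, most likely between 30000 nM and 110000 nM, and quite possibly again only a limit.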

Compound 4, half-maximal cytotoxic concentration: > 50000 nM
Compound 4 gave a limit, no number; the forecaster's own chance of this, stated with the estimate: 65%; the middle value does not contradict the limit.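

In this assay, compound 3 and compound 4 each give only a limit and not a number, so no step between them can be read: the limit of > 50000 nM in this assay, at which 2 of the 4 values shown sit.

The compounds shown leave open how far either compound lies beyond its limit, and whether chloro in place of bromo changes the result at all when it sits on the 3-chlorophenyl group of compound 4.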